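This account rests on a few compounds, and the source may have more. Where it says the series, first, only, none or still open, it means among the compounds named here.

In an ADME assay on microsomes from liver (Mus musculus, strain CD-1) for metabolic stability, read by LC-MS, using NADPH, with stated times of 5 min and 60 min, tested at 1 uM (on this read-out higher numbers stand for a longer-lived compound and lower numbers for a shorter-lived compound), compound 1 (`CCCCOC(=O)NS(=O)(=O)c1ccc(CCC)cc1-c1ccc(Cn2c(-c3nccs3)nc3ccccc32)cc1`) gives 0.0833 h. Within the data shown here, compound 2 (`CCCc1ccc(S(=O)(=O)NC(=O)OCCCC(F)(F)F)c(-c2cc(F)c(Cn3c(C(C)(C)C)nc4ccccc43)c(F)c2)c1`) gives 0.1 h, which lies within the usual scatter of the first number, and these are the only two measurements available. Compound 3 (`CCCCOC(=O)NS(=O)(=O)c1ccc(CCC)cc1-c1ccc(Cn2c(C)nc3ccccc32)cc1`) keeps the rest of compound 1 and changes one group: methyl in place of 1,3-thiazol-2-yl on an aromatic carbon, (methyl in place of 1,3-thiazol-2-yl on an aromatic carbon). Among the measured compounds shown here, no measured pair isolates this change, so the data do not show its effect on this assay directly. Differing from compound 1 in more than one place and lacking the 1,3-thiazol-2-yl group, compound 2 still gives 0.1 h, so a large gain is not expected. A small upward move, not clearly beyond the scatter, is expected: a 1.6-fold higher number from compound 1 to compound 3 (0.19 log units; within the scatter). For compound 3 the estimated half-life is 0.13 h, with an expected range of 0.08 h to 0.35 h.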

Compound 3, half-life: 0.0667 h
Estimate against measurement, compound 3: 1.9-fold (0.29 log units) above; the measured number lies below the stated range.
By their numbers in this assay, from the lowest: compounds 3, 1 and 2 (each within the scatter of the next).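

Among these compounds, this is the first measured pair that isolates methyl in place of 1,3-thiazol-2-yl on an aromatic carbon, and in this assay it gives a 1.2-fold lower number from compound 1 to compound 3 (0.10 log units; within the scatter) and so stays within the usual scatter. At this place, between two ring nitrogen atoms, a five-membered aromatic ring and a methyl therefore cannot be told apart by half-life, even though the two groups differ greatly in heavy atoms and hydrogen-bond acceptors. No measurement bears on why the half-life does not respond to this change.

As far as these compounds go, whether another group at this place, such as an amine, a carboxylic acid or a longer chain, would give a number beyond the scatter remains open. Also open, from the compounds shown here alone, is whether a change elsewhere on the shared core, such as a fluorine or a hydroxyl group, would move the half-life.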